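The source may report more compounds than this note shows. Statements on the series, on what has been measured and on what is new or still open speak of the compounds shown alone.

Of the compounds shown here, two have been measured in an assay on isolated protein for inhibition of vitamin D3 receptor (Homo sapiens); on this read-out lower numbers stand for stronger inhibition and higher numbers for weaker inhibition. Compound 1 `N=c1scc(-c2ccccc2)n1CC(=O)N1CCOCC1` gives 24400 nM, and compound 2 `Cc1ccc(-c2csc(=N)n2CC(=O)N2CCN(C)CC2)cc1` gives 17100 nM. Of the two numbers shown, that of compound 2 is the lower one, but its distance from the value of compound 1 is within the usual scatter, so the two cannot be told apart by this assay.

Compound 3 `Cc1ccc(-c2csc(=N)n2CC(=O)N2CCOCC2)cc1` is not yet measured. It is reached from compound 2 by one change: morpholin-4-yl in place of 4-methylpiperazin-1-yl on a carbonyl carbon. Among the compounds with values here, no measured pair shows this step directly. Since both measured compounds sit close together in this assay, compound 3 is expected to stay in the same weak region, with a step from compound 2 to compound 3 of a 1.2-fold higher number from compound 2 to compound 3 (0.07 log units; within the scatter), which is no more than the scatter. For compound 3 the estimate in this assay is 20000 nM, with a range from 7000 nM to 55000 nM.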

Compound 3, inhibition constant: 13700 nM
Compound 3: the middle estimate sits 1.5-fold (0.16 log units) above what was measured, within the range that was stated.
By their numbers in this assay, from the lowest: compounds 3, 2 and 1 (each within the scatter of the next).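

In this assay, morpholin-4-yl in place of 4-methylpiperazin-1-yl on a carbonyl carbon gives a 1.2-fold lower number from compound 2 to compound 3 (0.10 log units; within the scatter), which lies within the scatter, so the two groups cannot be told apart at this place. Methyl in place of hydrogen on an aromatic carbon, the first change here that can be read on its own, gives a 1.8-fold lower number from compound 1 to compound 3 (0.25 log units; within the scatter), and this too lies within the scatter. Nothing further is at hand that could explain these readings.

Going by these compounds, it remains open whether a piperidin-1-yl group, or a longer chain ending in a primary amine or a carboxylic acid, on the same carbonyl carbon would move the number beyond the scatter. The same question stands for chlorine or methoxy in place of methyl on the aromatic carbon.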